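This account rests on a few compounds, and the source may have more. Where it says the series, first, only, none or still open, it means among the compounds named here.

Measured so far in a functional assay on HCC1806 cells (Homo sapiens) for inhibition, read by sulforhodamine B assay, tested at 10 uM; a higher number here means more inhibition at the concentration tested (going by the name of the read-out), a lower number less inhibition:
- compound 1 `CN1CCN(c2ccc(C3=NN(S(=O)(=O)c4ccc(OC(F)(F)F)cc4)C(c4ccc(N(C)C)cc4)C3)cc2)CC1` gives 70.8%
- compound 2 `CN(C)c1ccc(C2CC(c3ccc(-n4cncn4)cc3)=NN2C(=O)c2cc(Cl)cc(Cl)c2)cc1` gives 5.3%

Compound 2 stands lowest of the two numbers. Its nearest neighbour is compound 1, whose value lies well above it, beyond the usual scatter. Going by the values given here, no single-place step between the two measured compounds can be drawn, as they differ in more than one place.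

Compound 3 `CN(C)c1ccc(C2CC(c3ccc(-n4cncn4)cc3)=NN2S(=O)(=O)c2ccc(C#N)cc2)cc1` is not yet measured. It differs from compound 2 in one place: (4-cyanophenyl)sulfonyl in place of (3,5-dichlorophenyl)carbonyl on an amine nitrogen in a ring. The group that enters is a sulfonyl on the amine nitrogen in the ring, and compound 1 also carries a sulfonyl-type group on the amine nitrogen in the ring, although compound 1 differs from compound 3 elsewhere as well, so the comparison is indirect.

The step from compound 2 to compound 3 in this assay is expected to be upward and beyond the scatter, a number 34.7 percentage points higher from compound 2 to compound 3 (beyond the scatter), because compound 1 gives 70.8% with a related sulfonyl. Compound 3 is accordingly expected at 40%, with a range of 8% to 75%. The wide range reflects the single, indirect anchor.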

Compound 3, a percentage reported as inhibition, at one concentration (the size of the read-out at that concentration, not a potency): 33.1%
For compound 3 the middle estimate is 6.9 percentage points above the measured one, and the stated range covers the measured number.
By their numbers in this assay, from the lowest: compound 2; then compound 3; then compound 1.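

On the amine nitrogen in the ring, next to the ring atom that bears the 4-(dimethylamino)phenyl group, the exchange of (3,5-dichlorophenyl)carbonyl for (4-cyanophenyl)sulfonyl in this assay gives a number 27.8 percentage points higher from compound 2 to compound 3 (beyond the scatter) with the 4-(1H-1,2,4-triazol-1-yl)phenyl group held constant, so the read-out at this concentration responds to the group at this position. The exchange alters both the link to the nitrogen, carbonyl to sulfonyl, and the substitution on the phenyl ring, and this single step cannot divide the change between those two parts. No measurement on the reason for the step is available.

Open, on these data alone, is whether a (3,5-dichlorophenyl)sulfonyl or a (4-cyanophenyl)carbonyl group on the same nitrogen would separate the contributions of the link and the phenyl substitution, and whether a methylsulfonyl group, with no aromatic ring, or a sulfonyl bearing an aminophenyl group would hold the number. Compound 1 differs from compound 3 in more than one place, so the effects of its (4-(trifluoromethoxy)phenyl)sulfonyl group and its other ring substituent remain unseparated.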